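The source may report more compounds than this note shows. Statements on the series, on what has been measured and on what is new or still open speak of the compounds shown alone.

Compound 1 `CCOC(=O)c1cc(-c2cccc(OCc3ccccc3)c2)on1` was tested in an ADME assay on Vero cells (Chlorocebus sabaeus) for cytotoxicity, with a stated time of 72 h; a lower number here means a stronger inhibitor, a higher number a weaker inhibitor. In this assay compound 1 gives > 128000 nM, which is a limit of the assay rather than a number. Compound 2 `CCOC(=O)c1cc(-c2cccc(OCc3cccc(F)c3)c2)on1` gives > 128000 nM, also a limit. Compound 3 `CCOC(=O)c1cc(-c2cccc(OCc3cccc(Br)c3)c2)on1` gives > 128000 nM, again a limit. The steps a step that the two limits leave unreadable from compound 1 to compound 2, a step that the two limits leave unreadable from compound 1 to compound 3 and a step that the two limits leave unreadable from compound 2 to compound 3 are therefore all unreadable, since (the limit of > 128000 nM in this assay, at which 3 of the 3 values shown sit). Compound 4 `CCOC(=O)c1cc(-c2cccc(OCc3ccccc3C(F)(F)F)c2)on1` differs from compound 1 by trifluoromethyl in place of hydrogen on an aromatic carbon. Among the measured compounds shown here, no measured step resolves a halogen or related change on this benzyl ring, so no step beyond the scatter is expected, and the result will most likely sit at the limit again. Compound 4 is expected to give about 128000 nM, within 64000 nM to 256000 nM. This estimate means a step of a number no higher from compound 1 to compound 4 (the limit leaves the size open) in this assay.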

Compound 4, half-maximal inhibitory concentration: > 128000 nM
Compound 4: no number, only a limit (the forecaster's own chance of this, stated with the estimate: 85%); the middle value sits exactly at the limit.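

Compound 4 stands at a limit, as compound 1 does, so no step between them can be read: the limit of > 128000 nM in this assay, at which 4 of the 4 values shown sit.

The compounds shown leave open what effect, if any, the fluoro, bromo and trifluoromethyl changes have in this assay.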